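The compounds below may be only part of what the source reports. "The series", "measured", "known", "first", "only" and "open" are said of these compounds alone.

Measured in an ADME assay on Vero cells (Chlorocebus sabaeus) for cytotoxicity, read by MTT assay, with a stated time of 72 h; a higher number here means that more compound is tolerated, a lower number that less compound is tolerated:
- Compound 1 `CC(C)c1ccc(C(Nc2ccc(C3(C)NC(=O)c4ccccc4N3)cc2)c2nnnn2C2CCCCC2)cc1`: > 400000 nM, a limit and not a number
- Compound 2 `COc1cccc(-c2cc(-c3ccc(C4NC(=O)c5ccccc5N4)cc3)nc(N)n2)c1OC`: > 400000 nM, a limit and not a number
- Compound 3 `COc1cc(-c2cc(-c3ccc(C4NC(=O)c5ccccc5N4)cc3)nc(N)n2)cc(OC)c1OC`: 85900 nM

Compound 3 is the only one of these with an actual number, while the other two sit at a shared ceiling, (the limit of > 400000 nM in this assay, at which 2 of the 3 values shown sit).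

Compound 4 `Nc1nc(-c2ccc(Br)cc2)cc(-c2ccc(C3NC(=O)c4ccccc4N3)cc2)n1` has not yet been measured. It carries 4-bromophenyl in place of the 3,4,5-trimethoxyphenyl of compound 3, on an aromatic carbon: 4-bromophenyl in place of 3,4,5-trimethoxyphenyl on an aromatic carbon.

For the measured compounds named here, one measured step bears on this change: an at least 4.6-fold lower number from compound 2 to compound 3 (0.66 log units; beyond the scatter). That step brought in the same 3,4,5-trimethoxyphenyl that now leaves, and its size is only a minimum, since one end is a limit. Going by the values given here, no measured compound carries 4-bromophenyl, so the guide is indirect, and a modest move towards more compound being tolerated seems most likely.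

The expected change is a 2.1-fold higher number from compound 3 to compound 4 (0.32 log units; beyond the scatter). The estimate for compound 4 is 180000 nM, with an expected range from 60000 nM to 400000 nM.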

Compound 4, half-maximal cytotoxic concentration: > 400000 nM
Compound 4: only a limit was reported; the forecaster's own chance of this, stated with the estimate: 30%; middle value at least 2.2-fold (0.34 log units) away from the limit.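

In this assay, replacing 3,4,5-trimethoxyphenyl with 4-bromophenyl gives an at least 4.6-fold higher number from compound 3 to compound 4 (0.66 log units; beyond the scatter), so the drop seen earlier on bringing in 3,4,5-trimethoxyphenyl now has a counterpart in the opposite direction from a second, different group. Among the three compounds that differ only at this position, 3,4,5-trimethoxyphenyl in compound 3 is the one group that brings the number down into the measurable range, while 2,3-dimethoxyphenyl in compound 2 and 4-bromophenyl in compound 4 do not. The step between compound 2 and compound 4 cannot be read, and compound 3 stays the only compound with an actual number, the others being limits: the limit of > 400000 nM in this assay, at which 3 of the 4 values shown sit.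

From the compounds shown here alone, how far compound 2 and compound 4 really lie beyond that limit stays open, as does whether the lower number of compound 3 depends on the three methoxy groups together. Going by these compounds, the effect of a plain phenyl, a 4-chlorophenyl or a phenyl carrying an amine at this position is also open.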